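Working notes on compound 4 of the series

The compounds below may be only part of what the source reports. "The series", "measured", "known", "first", "only" and "open" are said of these compounds alone.

Measured in a functional assay on MCF7 cells (Homo sapiens) for cytotoxicity, read by MTT assay, with a stated time of 48 h; on this read-out higher numbers stand for weaker inhibition and lower numbers for stronger inhibition:
- compound 1 `O=C(CSc1nnc(-c2ccncc2)o1)N/N=C/c1ccc(O)cc1`: compound 1 gives 11700 nM
- compound 2 `COc1ccc(/C=N/NC(=O)CSc2nnc(-c3ccncc3)o2)cc1`: compound 2 gives 17600 nM
- compound 3 `O=C(CSc1nnc(-c2ccncc2)o1)N/N=C/c1ccccc1F`: compound 3 gives 21800 nM

Compound 3 carries the highest of the three numbers, but its steps to the other two are both within the scatter: a 1.2-fold higher number from compound 2 to compound 3 (0.09 log units; within the scatter) and a 1.9-fold higher number from compound 1 to compound 3 (0.27 log units; within the scatter). On these numbers the three compounds cannot be told apart.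

Compound 4 `O=C(CSc1nnc(-c2ccncc2)o1)N/N=C/c1cc(Br)cc(Br)c1O` differs from compound 3 in one place: 3,5-dibromo-2-hydroxyphenyl in place of 2-fluorophenyl on a carbon with a double bond to nitrogen.

Going by the values given here, the steps that bear on this change are those that also swap the aryl group on the carbon double-bonded to nitrogen, namely a 1.9-fold higher number from compound 1 to compound 3 (0.27 log units; within the scatter) and a 1.2-fold higher number from compound 2 to compound 3 (0.09 log units; within the scatter), and the smaller variation a 1.5-fold higher number from compound 1 to compound 2 (0.18 log units; within the scatter) on the same ring. None of them moved the read-out beyond the scatter. Nothing measured speaks to bromine on this ring, so the expectation rests on the observation that aryl swaps here have so far been flat. A step of about a 1.5-fold lower number from compound 3 to compound 4 (0.16 log units; within the scatter) is therefore expected, with no move beyond the scatter, in either direction. Compound 4 is estimated at 15000 nM, within the range 5000 nM to 45000 nM.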

Compound 4, half-maximal inhibitory concentration: 9010 nM
Beside the measured number, compound 4's estimate is 1.7-fold (0.22 log units) above it; the measured number falls inside the stated range.
By their numbers in this assay, from the lowest: compounds 4, 1, 2 and 3 (each within the scatter of the next, the first and the last beyond it).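

In this assay, the aryl group on the carbon with a double bond to nitrogen gives its first step beyond the scatter, with 3,5-dibromo-2-hydroxyphenyl in place of 2-fluorophenyl producing a 2.4-fold lower number from compound 3 to compound 4 (0.38 log units; beyond the scatter) and showing that this position is not entirely flat, although the size of the step is only modest. Going by these compounds alone, the same entering group gives a 2.0-fold lower number from compound 2 to compound 4 (0.29 log units; within the scatter) and a 1.3-fold lower number from compound 1 to compound 4 (0.11 log units; within the scatter) in place of the two para-free-of-comparison aryl groups named in those steps, so only one of the three comparisons clears the scatter and the separation does not extend across the series. No evidence is available that bears on the origin of this step.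

The compounds shown leave open whether the two bromines, the hydroxy group or both together account for the step, as 3,5-dibromo-2-hydroxyphenyl differs from 2-fluorophenyl in more than one feature and no compound here separates them. Also open, from the compounds shown here alone, is how this read-out would respond to an amine or a carboxylic acid on the same aryl ring, or to a mono-bromo counterpart of compound 4.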